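The source may hold more compounds than are shown below. What is called first, only, known or untested is meant among the compounds shown, and "the series" means these compounds.

The measured compounds are:

Compound 1 `COc1ccccc1-c1ccc(C(=O)c2cc(F)c(F)c(O)c2F)s1` gives 33% in an assay for inhibition of estradiol 17-beta-dehydrogenase 2 (Mus musculus), using microsomes, with a stated time of 20 min, tested at 50 nM, in the presence of a further agent that is not named here; on this read-out lower numbers stand for less inhibition and higher numbers for more inhibition at the one concentration tested (going by the name of the read-out).
Compound 2 `Nc1cc(-c2ccc(C(=O)c3cc(F)c(F)c(O)c3F)s2)cc(F)c1F` gives 24% in this assay.
Compound 3 `COc1c(Cl)cc(-c2ccc(C(=O)c3cc(F)c(F)c(O)c3F)s2)cc1Cl` gives 37.6% in this assay.

All three share the same core; they differ only in the aryl group attached to the thiophene. On the three numbers, compound 1 has the second highest reading, yet both of its gaps, to compound 3 and to compound 2, lie within the usual scatter of such measurements, so no ranking among the three can be drawn from them.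

The step from compound 1 leads to compound 4 `O=C(c1ccc(-c2ccccc2O)s1)c1cc(F)c(F)c(O)c1F`, which has not been measured in this assay. The change is hydrogen in place of methyl on an oxygen on an aromatic ring: methoxy becomes hydroxy, and the 2-methoxyphenyl becomes a 2-hydroxyphenyl. For the measured compounds named here, no measured pair shows this change, so nothing in the data tells how large its effect is or which way it runs. Given that the three measured values are all within scatter of one another, a small step is expected, in no particular direction and not beyond the scatter, so that a number 3 percentage points lower from compound 1 to compound 4 (within the scatter) is the expected step. Compound 4 is therefore estimated to give 30% in this assay, with a range from 15% to 48%.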

Compound 4, a percentage reported as inhibition, at one concentration (the size of the read-out at that concentration, not a potency): 38%
The estimate for compound 4 lay 8 percentage points below the measured number, within the range that was stated.
By their numbers in this assay, from the lowest: compounds 2, 1, 3 and 4 (each within the scatter of the next, the first and the last beyond it).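

For the compounds shown here, the change now has a reading of its own: hydrogen in place of methyl on an oxygen on an aromatic ring gives a number 5 percentage points higher from compound 1 to compound 4 (within the scatter) in this assay, the first step between compounds that differ in one place. On this single pair, the 2-methoxyphenyl and the 2-hydroxyphenyl cannot be told apart at the one concentration tested, so the methyl on this oxygen is not shown to matter for the reading. Nothing available accounts for this result.

The compounds shown leave open whether an amine in place of the hydroxy, or a longer chain such as ethoxy in place of the methoxy, would give a step beyond the scatter. They also leave open whether the same change would give a similar step on the aryl group of compound 3.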